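Aryl swap on the ring nitrogen: compound 3

The compounds below may be only part of what the source reports. "The series", "measured", "known", "first", "only" and "open" are said of these compounds alone.

Two members of the series are measured. Compound 1 `CCCNC(=O)c1cc(Oc2ccc(NC(=O)c3cc4cccnc4n(-c4ccc(F)cc4)c3=O)cc2)ccn1` carries 4-fluorophenyl on the aromatic nitrogen of the shared core, and in a functional assay on NCI-H460 cells (Homo sapiens) for antiproliferative activity, read by MTT assay, with a stated time of 72 h (a higher number here means a weaker inhibitor, a lower number a stronger inhibitor), compound 1 gives 120 nM. Compound 2 `CCCNC(=O)c1cc(Oc2ccc(NC(=O)c3cc4cccnc4n(-c4ccc(C(F)(F)F)cc4Cl)c3=O)cc2)ccn1` carries 2-chloro-4-(trifluoromethyl)phenyl at the same place; in this assay compound 2 gives 3170 nM, the highest of the two numbers, reached by a 26-fold higher number from compound 1 to compound 2 (1.42 log units; beyond the scatter).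

Compound 3 `CCCNC(=O)c1cc(Oc2ccc(NC(=O)c3cc4cccnc4n(-c4ccc(F)c(Cl)c4)c3=O)cc2)ccn1` follows from compound 2 by one change: 3-chloro-4-fluorophenyl in place of 2-chloro-4-(trifluoromethyl)phenyl on an aromatic nitrogen. Among the compounds with values here, the only measured step bearing on this is a 26-fold higher number from compound 1 to compound 2 (1.42 log units; beyond the scatter), which went the opposite way, from 4-fluorophenyl to the larger group. Compound 3 brings back a group of closer size to that of compound 1, keeping the fluorine of 4-fluorophenyl while adding one chlorine. The expectation is therefore a step down, an 11-fold lower number from compound 2 to compound 3 (1.02 log units; beyond the scatter), landing between the two measured values and nearer compound 1. For compound 3 the estimate in this assay is 300 nM, with a range of 80 nM to 1200 nM.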

Compound 3, half-maximal inhibitory concentration: 1600 nM
Beside the measured number, compound 3's estimate is 5.3-fold (0.73 log units) below it; the measured number lies above the stated range.
By their numbers in this assay, from the lowest: compound 1; then compounds 3 and 2 (each within the scatter of the next).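

In this assay, chloro in place of hydrogen on an aromatic carbon of the 4-fluorophenyl group is by itself enough for a large step, a 13-fold higher number from compound 1 to compound 3 (1.12 log units; beyond the scatter), so this position does not need a group as large as 2-chloro-4-(trifluoromethyl)phenyl to lose activity. The exchange of that group, with 11 heavy atoms, for 3-chloro-4-fluorophenyl, with 8, gives a 2.0-fold lower number from compound 2 to compound 3 (0.30 log units; within the scatter), so these two aryl groups cannot be told apart in this assay, and only 4-fluorophenyl stands apart from them. Nothing available explains the effect of the added chloro.

Going by these compounds, it remains open whether the chloro itself matters or any added group on this ring would do the same. Unsubstituted phenyl, or a methoxy or amino group in place of the chloro, would test this.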